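Replacing a Cyclic Sulfonamide With an Open Chain

A few compounds are considered here, and "the series" means these few. Any claim that something is new, unique, unknown or untested is made for them only; others in the source may bear on it.

Of the compounds shown here, three built on one shared core have been measured in an assay on CHO cells for displacement of a labelled ligand from prostaglandin D2 receptor 2 (Homo sapiens), read by scintillation counting; on this read-out lower numbers stand for stronger inhibition and higher numbers for weaker inhibition. Compound 1 `CCS(=O)(=O)c1ccc(C)c(C#Cc2cc(Cl)ccc2OCC(=O)O)c1` gives 8.6 nM. Compound 2 `Cc1ccc(S(=O)(=O)N(C)CCCN(C)C)cc1C#Cc1cc(Cl)ccc1OCC(=O)O` gives 287 nM. Compound 3 `Cc1ccc(S(=O)(=O)N2CCCCC2C)cc1C#Cc1cc(Cl)ccc1OCC(=O)O` gives 1.9 nM, the lowest of the three numbers: the step of a 4.5-fold lower number from compound 1 to compound 3 (0.66 log units; beyond the scatter) and the step of a 150-fold lower number from compound 2 to compound 3 (2.18 log units; beyond the scatter) both lie beyond the scatter, so compound 3 is the strongest binder of the measured set.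

Compound 4 `Cc1ccc(S(=O)(=O)N(C)CCN(C)C)cc1C#Cc1cc(Cl)ccc1OCC(=O)O` has not yet been measured. Relative to compound 3 the change is (2-(dimethylamino)ethyl)(methyl)amino in place of 2-methylpiperidin-1-yl on a sulfonyl sulfur. The closest measured comparison is compound 2, which carries a longer open chain of the same kind in the same place; the steps of a 33-fold higher number from compound 1 to compound 2 (1.52 log units; beyond the scatter) and a 150-fold lower number from compound 2 to compound 3 (2.18 log units; beyond the scatter) show that this open chain gave far weaker binding than either the ethyl group or the ring. Among the measured compounds shown here, whether the shorter chain of compound 4 behaves like the chain of compound 2 cannot be settled from one pair, but nothing among the measured compounds points the other way. The step of a 110-fold higher number from compound 3 to compound 4 (2.02 log units; beyond the scatter) is therefore expected to be large and towards weaker binding. For compound 4 the estimate in this assay is 200 nM, with a range from 50 nM to 800 nM.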

Compound 4, inhibition constant: 369 nM
Beside the measured number, compound 4's estimate is 1.8-fold (0.27 log units) below it; the measured number falls inside the stated range.
By their numbers in this assay, from the lowest: compound 3; then compound 1; then compounds 2 and 4 (each within the scatter of the next).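

In this assay, the group on the sulfonyl sulfur matters far more than its count of heavy atoms: 2-methylpiperidin-1-yl and (2-(dimethylamino)ethyl)(methyl)amino both hold 7, yet the exchange gives a 190-fold higher number from compound 3 to compound 4 (2.29 log units; beyond the scatter). Shortening the open chain makes no readable difference, since a 1.3-fold higher number from compound 2 to compound 4 (0.11 log units; within the scatter) leaves the two chains indistinguishable in this read-out. The comparison with the small ethyl group, a 43-fold higher number from compound 1 to compound 4 (1.63 log units; beyond the scatter), shows that weak binding is not confined to the longer chain of compound 2 but is shared by both chains ending in dimethylamino, with no compound shown going against this.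

Nothing available explains why these chains bind so much more weakly than the ring or the ethyl group. The compounds shown also leave open whether the loss follows the terminal dimethylamino group or the open chain itself: butyl(methyl)amino would test an open chain with no terminal amine, and 4-(dimethylamino)piperidin-1-yl would test that amine carried on a ring.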